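Swapping the benzyl arm of the best amide for an anilino link

A few compounds are considered here, and "the series" means these few. Any claim that something is new, unique, unknown or untested is made for them only; others in the source may bear on it.

Three amides share one core and differ only in the group on the anilide ring. Compound 1 `O=C(Nc1ccc(Br)cc1)c1csc(Cc2c(Cl)cccc2Cl)n1` gives 460 nM in an assay on CHO cells, read by calcium flux; on this read-out lower numbers stand for stronger inhibition and higher numbers for weaker inhibition. Compound 2 `N#Cc1ccc(NC(=O)c2csc(Cc3c(Cl)cccc3Cl)n2)cc1` gives 720 nM, and the step of a 1.6-fold higher number from compound 1 to compound 2 (0.19 log units; within the scatter). Compound 3 `O=C(Nc1ccc(C(F)(F)F)cc1)c1csc(Cc2c(Cl)cccc2Cl)n1` gives 88 nM, the lowest number of the three; the steps of a 5.2-fold lower number from compound 1 to compound 3 (0.72 log units; beyond the scatter) and an 8.2-fold lower number from compound 2 to compound 3 (0.91 log units; beyond the scatter) set it apart from both.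

Compound 4 `Cc1cccc(C)c1Nc1nc(C(=O)Nc2ccc(C(F)(F)F)cc2)cs1` keeps the trifluoromethyl anilide of compound 3 but changes the other arm of the core: (2,6-dimethylphenyl)amino in place of 2,6-dichlorobenzyl on an aromatic carbon. For the measured compounds named here, none of the three measured steps touches that position; all of them concern the substituent on the anilide ring, so the data offer no step that bears on this change, and no direction can be read from them. The estimate for compound 4 is therefore centred near compound 3 with a wide range, at 200 nM (from 40 nM to 1000 nM), which means an expected step of a 2.3-fold higher number from compound 3 to compound 4 (0.36 log units; beyond the scatter).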

Compound 4, half-maximal inhibitory concentration: 82 nM
For compound 4 the middle estimate is 2.4-fold (0.39 log units) above the measured one, and the stated range covers the measured number.
By their numbers in this assay, from the lowest: compounds 4 and 3 (each within the scatter of the next); then compounds 1 and 2 (each within the scatter of the next).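

Compound 4 shows that this position of the shared core, on the aromatic carbon next to the ring nitrogen and next to the ring sulfur, accepts more than one arm: in this assay, a 1.1-fold lower number from compound 3 to compound 4 (0.03 log units; within the scatter). For the compounds shown here, the earlier compounds varied only the anilide ring, so this is the first reading at this arm, and it finds (2,6-dimethylphenyl)amino and 2,6-dichlorobenzyl indistinguishable despite the hydrogen-bond donor and acceptor that the former brings. No measurement here explains why the two arms read alike.

The exchange alters the link and the ring substituents at once, so the compounds shown leave open how each contributes on its own. A phenylamino arm without the methyl groups would address that, and bromo or nitrile on the anilide ring of compound 4 would test whether the earlier anilide steps carry over to this arm.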